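A few compounds are considered here, and "the series" means these few. Any claim that something is new, unique, unknown or untested is made for them only; others in the source may bear on it.

Measured compounds:
Compound 1, `CCCCNC(=O)c1c(O)c2cccnc2n(-c2ccccc2)c1=O`: 12.8%
Compound 2, `COc1cccc(NC(=O)c2c(O)c3cccnc3n(-c3ccccc3)c2=O)c1`: 5.7%

Both compounds share one core and differ only in the group on an amide-type nitrogen. In a functional assay on the whole organism for inhibition, with Rattus norvegicus as the target, read by paw edema, at a dose of 100 mg/kg by the oral route (on this read-out higher numbers stand for more inhibition at the one dose given (going by the name of the read-out) and lower numbers for less inhibition), compound 1 gives 12.8%, and compound 2 gives 5.7%. The step of a number 7.1 percentage points lower from compound 1 to compound 2 (within the scatter) lies within the scatter, so compound 2 and compound 1 cannot be told apart on these numbers; compound 2 simply sits at the lower end of the two values shown.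

Compound 3, `O=C(NCc1cccnc1)c1c(O)c2cccnc2n(-c2ccccc2)c1=O`, continues the series at the same place. The change is (pyridin-3-yl)methyl in place of 3-methoxyphenyl on an amide-type nitrogen. Going by the values given here, the only measured step that bears on it is the one at the same nitrogen, a number 7.1 percentage points lower from compound 1 to compound 2 (within the scatter), which exchanged a chain for an aromatic ring without moving the read-out beyond the scatter. On that single precedent, no step beyond the scatter is expected here either, in either direction. The step of a number 3.3 percentage points higher from compound 2 to compound 3 (within the scatter) is therefore estimated to stay within the scatter. Compound 3 is expected to give about 9%, with a range from 0% to 25%.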

Compound 3, a percentage reported as inhibition, in the whole organism at one dose (the size of the read-out at that dose, not a potency): 25.5%
Beside the measured number, compound 3's estimate is 16.5 percentage points below it; measured number above the stated range.
By their numbers in this assay, from the lowest: compounds 2 and 1 (each within the scatter of the next); then compound 3.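

In this assay, the group on the amide-type nitrogen now shows that it can change the result beyond the scatter: (pyridin-3-yl)methyl gives a number 19.8 percentage points higher from compound 2 to compound 3 (beyond the scatter), and also a number 12.7 percentage points higher from compound 1 to compound 3 (beyond the scatter). An aromatic ring on this nitrogen is not enough by itself to produce this rise, since compound 2 also carries one and stays within the scatter of compound 1, so the difference must lie in what sets compound 3 apart: a ring holding a nitrogen atom, joined to the amide nitrogen through a saturated carbon. No measurement on hand gives a reason for this rise.

The step from compound 2 changes the ring and its attachment together, so these compounds cannot show which change matters, or whether both are needed. A benzyl group would test the saturated carbon with an all-carbon ring, while a pyridin-3-yl ring bound directly to the amide nitrogen would test the ring nitrogen without that carbon, and a 2-(pyridin-3-yl)ethyl group would show whether a longer chain keeps the higher number.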